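From a Pyridine to an Imidazole: Estimating Compound 4

The compounds below may be only part of what the source reports. "The series", "measured", "known", "first", "only" and "open" are said of these compounds alone.

Three compounds have been measured in an assay on microsomes from intestine for inhibition of acyl-CoA:cholesterol acyltransferase (Oryctolagus cuniculus); a higher number here means a weaker inhibitor, a lower number a stronger inhibitor:
Compound 1 `CN(C)c1ccc(CN(Cc2cccc(-c3cc[nH]n3)c2)C(=O)Nc2c(F)cc(F)cc2F)cc1` gives 12 nM.
Compound 2 `Cc1cc(C)c(NC(=O)N(Cc2ccc(-c3cccnc3)cc2)C2CCCCCC2)c(C)c1` gives 130 nM.
Compound 3 `Cc1cc(C)c(NC(=O)N(Cc2cccc(-c3ccnn3C)c2)C2CCCCCC2)c(C)c1` gives 35 nM.

Compound 2 stands at the highest number of the three and is the weakest inhibitor here: its nearest neighbour, compound 3, lies beyond the scatter below it, and compound 1 lies further still. Compound 4 `Cc1cc(C)c(NC(=O)N(Cc2ccc(-n3ccnc3)cc2)C2CCCCCC2)c(C)c1` has not been measured. It differs from compound 2 in one place: 1H-imidazol-1-yl in place of pyridin-3-yl on an aromatic carbon. Among the measured compounds shown here, no measured pair shows this exact change, so no directly comparable step exists. The step expected from compound 2 to compound 4 is a 1.3-fold lower number from compound 2 to compound 4 (0.11 log units; within the scatter), most likely within the scatter and with no clear direction. Compound 4 is therefore estimated at 100 nM, within a range from 30 nM to 350 nM.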

Compound 4, half-maximal inhibitory concentration: 47 nM
The estimate for compound 4 lay 2.1-fold (0.33 log units) above the measured number; measured number inside the range.
By their numbers in this assay, from the lowest: compound 1; then compounds 3 and 4 (each within the scatter of the next); then compound 2.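

At this position, para to a large group, 1H-imidazol-1-yl in place of pyridin-3-yl gives a 2.8-fold lower number from compound 2 to compound 4 (0.44 log units; beyond the scatter) in this assay. Among the compounds shown here, this is the first step in the set that changes one place only, and it shows that the ring on this aromatic carbon matters: the five-membered ring gives the stronger inhibitor here. Nothing measured here explains the change.

As far as these compounds go, whether ring size or the number of ring nitrogens carries this step stays open. A phenyl ring or a 1H-pyrrol-1-yl group at this position could help separate the two.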